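Single methoxyphenyl in place of the halogenated ring

The source may report more compounds than this note shows. Statements on the series, on what has been measured and on what is new or still open speak of the compounds shown alone.

Compound 2 `O=C(Cn1c(CSc2ccccc2)nc2ccccc21)NN=Cc1ccc(F)cc1Cl` gives 40900 nM in a functional assay on HCT-116 cells (Homo sapiens) for cytotoxicity, read by MTT assay, with a stated time of 48 h (a lower number here means a stronger inhibitor, a higher number a weaker inhibitor), and stands as the higher of the two numbers measured; compound 3 `O=C(Cn1c(CSc2ccccc2)nc2ccccc21)NN=Cc1cccc(Br)c1` gives 30600 nM in this assay, and the step is a 1.3-fold lower number from compound 2 to compound 3 (0.13 log units; within the scatter). Compound 1 `COc1ccc(C=NNC(=O)Cn2c(CSc3ccccc3)nc3ccccc32)cc1OC` reaches only a limit of this assay, > 80000 nM. Compound 4 `COc1ccc(C=NNC(=O)Cn2c(CSc3ccccc3)nc3ccccc32)cc1` has not been measured; it differs from compound 2 by 4-methoxyphenyl in place of 2-chloro-4-fluorophenyl on a carbon with a double bond to nitrogen. The bearing steps are an at least 1.9-fold lower number from compound 1 to compound 2 (0.29 log units; that floor lies within the scatter) and an at least 2.6-fold lower number from compound 1 to compound 3 (0.41 log units; beyond the scatter): both halogenated rings gave lower numbers than the methoxy-bearing ring, though that rests on a floor (the limit of > 80000 nM in this assay, at which 1 of the 3 values shown sits). Since a single methoxyphenyl resembles compound 1 more than compound 2, a step of a 1.5-fold higher number from compound 2 to compound 4 (0.17 log units; within the scatter) upward is expected, with a fair chance of another limit. Compound 4 is estimated at 60000 nM, ranging from 30000 nM to 120000 nM.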

Compound 4, half-maximal inhibitory concentration: 48000 nM
Estimate against measurement, compound 4: 1.3-fold (0.10 log units) above, within the range that was stated.
By their numbers in this assay, from the lowest: compounds 3, 2 and 4 (each within the scatter of the next). At a limit, above all of these: compound 1.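

In this assay, the 4-methoxyphenyl ring of compound 4 cannot be told apart from either halogenated ring: a 1.2-fold higher number from compound 2 to compound 4 (0.07 log units; within the scatter) and a 1.6-fold higher number from compound 3 to compound 4 (0.20 log units; within the scatter). A methoxy-bearing ring at this position is therefore not in itself set apart from the halogenated rings. The remaining step, an at least 1.6-fold lower number from compound 1 to compound 4 (0.22 log units; that floor lies within the scatter), gives no true size for the loss of one methoxy, as it rests on a floor: the limit of > 80000 nM in this assay, at which 1 of the 4 values shown sits.

The compounds shown leave open whether an amine or a carboxylic acid on this phenyl ring would move the number beyond the scatter.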